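The compounds below may be only part of what the source reports. "The series", "measured", "known", "first", "only" and "open" are said of these compounds alone.

Measured so far:
- compound 1, `CCN1CCN(c2cc(C)c3cc(NC(=O)c4ccc[nH]4)ccc3n2)CC1`: 13200 nM
- compound 2, `Cc1cc(NCCN2CCCC2)nc2ccc(NC(=O)c3ccc(Cl)c(Cl)c3)cc12`: 9530 nM

In a functional assay on SK-BR-3 cells (Homo sapiens) for antiproliferative activity, read by MTT assay, with a stated time of 72 h (a higher number here means a weaker inhibitor, a lower number a stronger inhibitor), compound 1 gives 13200 nM, the highest of the two numbers in hand. Its nearest neighbour is compound 2, which in this assay gives 9530 nM; the two numbers lie within the usual scatter of each other, so no order between them can be read. Both are weak inhibitors on this read-out.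

Compound 3, `CCN1CCN(c2cc(C)c3cc(NC(=O)c4cccc(Br)c4)ccc3n2)CC1`, keeps the core of compound 1 and changes only the group on the amide carbonyl: 3-bromophenyl in place of 1H-pyrrol-2-yl on a carbonyl carbon

Within the data shown here, no measured pair shows this change, so its size is unknown. Among the measured compounds shown here, the only guide is compound 2, where a halogenated phenyl on the amide carbonyl sits in the same weak range as the pyrrole amide of compound 1. The step from compound 1 to compound 3 in this assay is therefore expected to be small, if anything towards a slightly lower number, and likely within the scatter. Compound 3 is estimated at 8000 nM, with a range from 2500 nM to 25000 nM; the expected step is a 1.7-fold lower number from compound 1 to compound 3 (0.22 log units; within the scatter).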

Compound 3, half-maximal inhibitory concentration: 13300 nM
For compound 3 the middle estimate is 1.7-fold (0.22 log units) below the measured one, within the range that was stated.
By their numbers in this assay, from the lowest: compounds 2, 1 and 3 (each within the scatter of the next).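

On the amide carbonyl of the core of compound 1, the first pair differing in one place gives, in this assay, a 1.0-fold higher number from compound 1 to compound 3 (0.00 log units; within the scatter), so 3-bromophenyl in place of 1H-pyrrol-2-yl on a carbonyl carbon leaves the number within the scatter. A five-membered aromatic ring with a hydrogen-bond donor and a six-membered aromatic ring of carbon only, bearing bromine, thus cannot be told apart at this place on this read-out, a comparison that compounds 1 and 2 alone could not offer, as they differ in more than one place. No measurement in hand bears on why this step is so small.

Still open, from the compounds shown here alone, is whether any group on this carbonyl can move the number beyond the scatter, for instance a pyridine ring, a phenyl ring carrying an amine or a carboxylic acid, or a saturated alkyl chain. Also open, going by these compounds, is what the group on the other side of the shared core contributes, since the steps linking compound 2 to compound 1 or compound 3 cannot be read, and a longer amine chain there would need its own matched partner.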